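Replacing the 2,4-dichlorophenyl group of compound 3

The source may hold more compounds than are shown below. What is called first, only, known or untested is meant among the compounds shown, and "the series" means these compounds.

Among the measured compounds shown here, in a functional assay on RAW264.7 cells (Mus musculus) for cytotoxicity, read by MTT assay, with a stated time of 48 h (on this read-out higher numbers stand for weaker inhibition and lower numbers for stronger inhibition), compound 1 `CS(=O)(=O)c1ccc(Cc2nnc3n2N=C(c2ccc(-c4ccccc4)cc2)CS3)cc1` gives 12500 nM, the only exact number so far. Compound 2 `CS(=O)(=O)c1ccc(Cc2nnc3n2N=C(c2cc(Cl)sc2Cl)CS3)cc1` reaches only a limit of the assay, > 100000 nM. Compound 3 `CS(=O)(=O)c1ccc(Cc2nnc3n2N=C(c2ccc(Cl)cc2Cl)CS3)cc1` also reaches only a limit, > 100000 nM. Compound 4 `Cc1ccc(C2=Nn3c(Cc4ccc(S(C)(=O)=O)cc4)nnc3SC2)cc1` keeps the shared core and changes one group: 4-methylphenyl in place of 2,4-dichlorophenyl on a carbon with a double bond to nitrogen. The closest measured change, a step that the two limits leave unreadable from compound 2 to compound 3, swaps a group on that same carbon but gives no size to build on. Compound 1, at 12500 nM, shows that another group on that carbon can give a readable value, so a number is possible, but little change is expected. The expected step is a number no higher from compound 3 to compound 4 (the limit leaves the size open). For compound 4, the estimated value is 100000 nM, with an expected range of 30000 nM to 300000 nM.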

Compound 4, half-maximal inhibitory concentration: > 100000 nM
Compound 4: only a limit was reported; the forecaster's own chance of this, stated with the estimate: 65%; the middle value sits exactly at the limit.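

Compound 4 gives only a limit in this assay, so 4-methylphenyl, like the two dichlorinated groups, yields no exact number at this position. Methyl in place of phenyl on an aromatic carbon gives an at least 8.0-fold higher number from compound 1 to compound 4 (0.90 log units; beyond the scatter), the first step with a readable size here, and it ties the exact value of compound 1 to its added phenyl ring. The steps among compound 2, compound 3 and compound 4 cannot be read, and a single limit covers all three: the limit of > 100000 nM in this assay, at which 3 of the 4 values shown sit.

As far as these compounds go, whether an amine, a carboxylic acid or a longer chain in place of that methyl would give an exact number stays open. Among the compounds shown here, with only one exact value, the compounds at the limit cannot be placed in any order.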